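The compounds below may be only part of what the source reports. "The series", "measured", "known", "first", "only" and "open" are said of these compounds alone.

Compound 3 `Cc1n[nH]c(C(=O)O)c1Cc1ccccc1C(F)(F)F` gives 13% in an assay on isolated protein for inhibition of 2-Hydroxyacid oxidase 2 (Homo sapiens), tested at 1 uM (on this read-out lower numbers stand for a weaker effect and higher numbers for a stronger effect at the one concentration tested), the highest of the three numbers at hand. Compound 1 `Cc1n[nH]c(C(=O)O)c1Cc1ccccc1-c1ccc(F)cc1` gives 11%, and the step of a number 2 percentage points higher from compound 1 to compound 3 (within the scatter) lies within the scatter. Compound 2 `Cc1n[nH]c(C(N)=O)c1Cc1cccc(-c2ccc(F)cc2)c1` gives 1%, a number beyond the scatter below that of compound 3. Compound 4 `Cc1n[nH]c(C(=O)O)c1Cc1ccccc1Oc1ccccc1` differs from compound 3 by phenoxy in place of trifluoromethyl on an aromatic carbon. Within the data shown here, the only measured step at this place, a number 2 percentage points higher from compound 1 to compound 3 (within the scatter), exchanged one group for another without moving the number beyond the scatter, so no step beyond the scatter is expected in this assay from compound 3 to compound 4 either, with the sign left open. Compound 4 is therefore estimated at 12%, between 2% and 28%, an expected step of a number 1 percentage points lower from compound 3 to compound 4 (within the scatter).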

Compound 4, a percentage reported as inhibition, at one concentration (the size of the read-out at that concentration, not a potency): 9%
Compound 4: the middle estimate sits 3 percentage points above what was measured; the measured number falls inside the stated range.
By their numbers in this assay, from the lowest: compounds 2, 4, 1 and 3 (each within the scatter of the next, the first and the last beyond it).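

Phenoxy in place of trifluoromethyl on this aromatic carbon gives a step (a number 4 percentage points lower from compound 3 to compound 4 (within the scatter)), and phenoxy in place of 4-fluorophenyl gives another (a number 2 percentage points lower from compound 1 to compound 4 (within the scatter)), so in this assay a ring attached through oxygen joins the two earlier groups without any step beyond the scatter. All three exchanges among compounds 1, 3 and 4 now lie within the scatter, whichever group leaves. Nothing at hand explains this. On these data alone, whether an amine or a nitrile at this place would move the number beyond the scatter stays open. So does the part played by the carboxylic acid, since compound 2 differs from these compounds in more than one place.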